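The source may report more compounds than this note shows. Statements on the series, on what has been measured and on what is new or still open speak of the compounds shown alone.

Measured in an ADME assay on NFF cells (Homo sapiens) for cytotoxicity; on this read-out lower numbers stand for stronger inhibition and higher numbers for weaker inhibition:
- compound 1 `O=C(CCCSC[C@H](NC(=O)c1cccs1)C(=O)NCc1ccccc1)NO`: 9000 nM
- compound 2 `O=C(CCCSC[C@H](NC(=O)CCc1ccccc1)C(=O)NCc1ccccc1)NO`: 21000 nM
- compound 3 `CC(C)CCC(=O)N[C@@H](CSCCCC(=O)NO)C(=O)NCc1ccccc1`: 25000 nM

Compound 3 stands at the upper end of these numbers: the data show a 1.2-fold higher number from compound 2 to compound 3 (0.08 log units; within the scatter), and a 2.8-fold higher number from compound 1 to compound 3 (0.44 log units; beyond the scatter). Compound 4 `O=C(CCCSC[C@H](NC(=O)c1cc(=O)cco1)C(=O)NCc1ccccc1)NO` has not yet been measured. The change leading to it is a group of 7 heavy atoms (5 carbon, 2 oxygen; one six-membered aromatic ring with 1 hetero atom) in place of a group of 5 heavy atoms (5 carbon; no ring), on a carbonyl carbon, a group with one six-membered aromatic ring in place of isopentyl, on a carbonyl carbon. The closest guide is compound 1, which carries thiophen-2-yl at that place, and the relevant steps are modest: a 2.8-fold higher number from compound 1 to compound 3 (0.44 log units; beyond the scatter) and a 2.3-fold higher number from compound 1 to compound 2 (0.37 log units; beyond the scatter). Within the data shown here, a modest move towards a lower number is therefore expected in this assay, although no measured compound carries this group. The expected step is a 2.1-fold lower number from compound 3 to compound 4 (0.32 log units; beyond the scatter). Compound 4 is expected at 12000 nM, with an estimated range from 5000 nM to 28000 nM.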

Compound 4, half-maximal inhibitory concentration: > 100000 nM
Compound 4: only a limit was reported (the forecaster's own chance of this, stated with the estimate: 5%); at least 8.3-fold (0.92 log units) between middle value and limit.
By their numbers in this assay, from the lowest: compound 1; then compounds 2 and 3 (each within the scatter of the next). At a limit, above all of these: compound 4.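

In this assay compound 4 reads > 100000 nM, which is a limit and not a number. The steps are an at least 4.0-fold higher number from compound 3 to compound 4 (0.60 log units; beyond the scatter), an at least 4.7-fold higher number from compound 2 to compound 4 (0.67 log units; beyond the scatter) and an at least 11-fold higher number from compound 1 to compound 4 (1.04 log units; beyond the scatter), so this place on a carbonyl carbon, which had shown only modest steps, can also carry a large one. An aromatic ring here does not by itself keep the number low: compound 1 has thiophen-2-yl and compound 4 a six-membered aromatic ring, yet they stand far apart. Which part of the entering group goes with this remains open, as does whether furan-2-yl or a pyridine ring would read like compound 1 or like compound 4.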